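The source may hold more compounds than are shown below. What is called first, only, known or untested is meant among the compounds shown, and "the series" means these compounds.

Compound 1, `CS(=O)(=O)c1ccc(-c2cnc3[nH]cc(-c4nnc(-c5ccc(F)cc5)o4)c(=O)c3c2)cc1`, gives 11.1% in a functional assay on HepG2 cells (Homo sapiens) for inhibition, read by MTT assay, with a stated time of 24 h, tested at 10 uM; a higher number here means more inhibition of growth at the concentration tested, a lower number less inhibition of growth.
Compound 2, `CS(=O)(=O)c1ccc(-c2cnc3[nH]cc(-c4nnc(-c5ccc(Cl)cc5)o4)c(=O)c3c2)cc1`, gives 11.6%.
Compound 3, `Cc1ccc(-c2nnc(-c3c[nH]c4ncc(-c5ccc(S(C)(=O)=O)cc5)cc4c3=O)o2)cc1`, gives 8.94%.

Compound 3 stands close to both others: a number 2.2 percentage points lower from compound 1 to compound 3 (within the scatter) and a number 2.7 percentage points lower from compound 2 to compound 3 (within the scatter), so the three numbers cannot be told apart. Compound 4, `Cc1cccc(-c2nnc(-c3c[nH]c4ncc(-c5ccc(S(C)(=O)=O)cc5)cc4c3=O)o2)c1`, differs from compound 3 in one place: 3-methylphenyl in place of 4-methylphenyl on an aromatic carbon. Within the data shown here, the only steps measured so far all exchange the group on that same phenyl ring, and each stayed within the scatter: a number 0.5 percentage points higher from compound 1 to compound 2 (within the scatter) beside the two just named. Among the measured compounds shown here, no measured step moves a substituent around that ring, but nothing in these numbers points to a change beyond the scatter. Compound 4 is therefore expected to show a number 1.1 percentage points higher from compound 3 to compound 4 (within the scatter), an estimated 10% with a range of 2% to 18%.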

Compound 4, percent growth inhibition at one concentration: 13.3%
Compound 4: the middle estimate sits 3.3 percentage points below what was measured, and the stated range covers the measured number.
By their numbers in this assay, from the lowest: compounds 3, 1, 2 and 4 (each within the scatter of the next).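

Among these compounds, compound 4 adds the first measured step that moves a group around the phenyl ring rather than exchanging it, and in this assay the change to 3-methylphenyl from 4-methylphenyl stays inside the scatter (a number 4.4 percentage points higher from compound 3 to compound 4 (within the scatter)). The exchanges for 4-chlorophenyl (a number 1.7 percentage points higher from compound 2 to compound 4 (within the scatter)) and 4-fluorophenyl (a number 2.2 percentage points higher from compound 1 to compound 4 (within the scatter)) stay inside it too, so the four compounds cannot be told apart. Nothing available accounts for these numbers.

From the compounds shown here alone, whether an amine or a carboxylic acid on this phenyl ring, or a longer chain in place of the methyl, would give a step beyond the scatter stays open.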